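Adding a 4-Bromobenzyl Group to an Inactive Sulfonamide

The compounds below may be only part of what the source reports. "The series", "measured", "known", "first", "only" and "open" are said of these compounds alone.

Compound 1, `CCOC(=O)c1oc2ccc(NS(=O)(=O)c3ccc(Br)cc3)cc2c1C`, was tested in a functional assay on HCT-116 cells (Homo sapiens) for inhibition, read by MTT assay, with a stated time of 72 h; on this read-out lower numbers stand for stronger inhibition and higher numbers for weaker inhibition. In this assay compound 1 gives > 40000 nM, which is a limit of the assay and not a measured number. Two close relatives end the same way. Compound 2, `CCOC(=O)c1oc2ccc(NS(=O)(=O)c3ccc(Cl)cc3)cc2c1C`, gives > 40000 nM in this assay, again a limit. Compound 3, `CCOC(=O)c1oc2ccc(NS(=O)(=O)c3ccc(F)cc3)cc2c1C`, gives > 40000 nM in this assay, also a limit. Because all three values sit at the limit of > 40000 nM in this assay, at which 3 of the 3 values shown sit, the steps between them cannot be sized: a step that the two limits leave unreadable from compound 1 to compound 2, a step that the two limits leave unreadable from compound 1 to compound 3 and a step that the two limits leave unreadable from compound 2 to compound 3 all stay unreadable. Compound 1 therefore stands at the limit, with nothing to rank it against compounds 2 and 3.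

Compound 4, `CCOC(=O)c1oc2ccc(N(Cc3ccc(Br)cc3)S(=O)(=O)c3ccc(Br)cc3)cc2c1C`, differs from compound 1 by 4-bromobenzyl in place of hydrogen on a sulfonamide nitrogen. Among the measured compounds shown here, the three measured steps each swap one halogen for another on an aromatic carbon, a different place from the sulfonamide nitrogen, and none of them has a readable size; so no measured step bears on this change, and the data give neither a size nor a direction to expect in this assay. With the starting point itself at a limit, compound 4 is expected to give 30000 nM, within a range of 5000 nM to 100000 nM. That estimate corresponds to an expected step of an at least 1.3-fold lower number from compound 1 to compound 4 (0.12 log units; that floor lies within the scatter).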

Compound 4, half-maximal inhibitory concentration: 5220 nM
Beside the measured number, compound 4's estimate is 5.7-fold (0.76 log units) above it, within the range that was stated.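

In this assay, among the compounds shown here, 4-bromobenzyl in place of hydrogen on the sulfonamide nitrogen gives an at least 7.6-fold lower number from compound 1 to compound 4 (0.88 log units; beyond the scatter), the only step in this set with a readable size. The sulfonamide nitrogen is therefore a place where a change can move this read-out, which the swaps of one halogen for another could not show, as the steps among compounds 1, 2 and 3 cannot be read. The size printed for this step is only a floor, because the value of compound 1 is a limit and not a measured number: the limit of > 40000 nM in this assay, at which 3 of the 4 values shown sit.

The compounds shown leave open which part of the new group matters, since a plain benzyl group without bromine, a small methyl group, a longer alkyl chain or a chain ending in an amine on the same nitrogen would each help separate the role of the ring from that of the bromine. They also leave open whether the chloro and fluoro relatives, compounds 2 and 3, would respond in the same way to 4-bromobenzyl on that nitrogen.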